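Swapping Diethylamino for Butylamino on the Shared Core

This account rests on a few compounds, and the source may have more. Where it says the series, first, only, none or still open, it means among the compounds named here.

Of the compounds shown here, two have been measured in an in vitro assay on 293-EBNA cells for binding affinity to corticotropin-releasing factor receptor 1 (Homo sapiens); on this read-out higher numbers stand for weaker inhibition and lower numbers for stronger inhibition. Compound 1 `CCC(CC)Nc1nc(C)nc2c1nnn2-c1c(C)cc(C)cc1C` gives 5.7 nM in this assay. Compound 2 `CCN(CC)c1nc(C)nc2c1nnn2-c1ccc(C(C)C)cc1Br` gives 25.3 nM in this assay, the higher of the two numbers, with the gap to compound 1 lying beyond the usual scatter. The two compounds differ in more than one place, so their values show only where each stands.

Compound 3 `CCCCNc1nc(C)nc2c1nnn2-c1ccc(C(C)C)cc1Br` is not yet measured. It differs from compound 2 by one change: butylamino in place of diethylamino on an aromatic carbon. Compound 3 thus keeps the core of compound 2 and the same count of heavy atoms in the side chain, while gaining one hydrogen-bond donor.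

For the measured compounds named here, with no single-place step among the measured compounds to lean on, the step of a 1.4-fold lower number from compound 2 to compound 3 (0.15 log units; within the scatter) is expected to be modest, at most a mild lowering of the number. For compound 3 the estimate in this assay is 18 nM, with a range from 6 nM to 55 nM.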

Compound 3, inhibition constant: 69.6 nM
Estimate against measurement, compound 3: 3.9-fold (0.59 log units) below; the measured number lies above the stated range.
By their numbers in this assay, from the lowest: compound 1; then compound 2; then compound 3.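

In this assay, this is the first single-place step among these compounds: on an aromatic carbon next to the ring nitrogen, butylamino in place of diethylamino gives a 2.8-fold higher number from compound 2 to compound 3 (0.44 log units; beyond the scatter) and so moves the number upward, beyond the scatter. The position therefore distinguishes between two side chains built from the same atoms, joined differently. Butylamino carries a hydrogen-bond donor and diethylamino carries none, but this single step cannot separate that difference from the change in chain shape, and no available data explain the rise.

The compounds shown leave open how a longer chain such as hexylamino, or a cyclic amine such as morpholine, would read at this position. They also leave open whether the same swap would give a similar step with the aromatic ring of compound 1 in place of that of compound 2.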